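Chloro to nitro on the shared core

The source may hold more compounds than are shown below. What is called first, only, known or untested is meant among the compounds shown, and "the series" means these compounds.

- Compound 1 `Nc1n[n+]([O-])c2c(F)cccc2[n+]1[O-]` gives 2100 nM
- Compound 2 `Nc1n[n+]([O-])c2cc(Cl)ccc2[n+]1[O-]` gives 730 nM

Among the compounds with values here, in a functional assay on HT-29 cells (Homo sapiens) for inhibition (on this read-out higher numbers stand for weaker inhibition and lower numbers for stronger inhibition), compound 2 stands at 730 nM, the lower of the two numbers so far and beyond the scatter from compound 1 . Compound 3 `Nc1n[n+]([O-])c2cc([N+](=O)[O-])ccc2[n+]1[O-]` carries nitro in place of chloro on an aromatic carbon. Within the data shown here, no measured pair isolates a change at this place, so the step is a judgement: a moderate move towards stronger inhibition, beyond the scatter, is expected. The expected step is a 2.4-fold lower number from compound 2 to compound 3 (0.39 log units; beyond the scatter). Compound 3 is estimated at 300 nM, with an expected range of 90 nM to 1000 nM.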

Compound 3, half-maximal inhibitory concentration: 790 nM
Compound 3: middle estimate off by 2.6-fold (0.42 log units), on the low side, within the range that was stated.
By their numbers in this assay, from the lowest: compounds 2 and 3 (each within the scatter of the next); then compound 1.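

In this assay, within the data shown here, nitro in place of chloro on this aromatic carbon gives a 1.1-fold higher number from compound 2 to compound 3 (0.03 log units; within the scatter), the first step that isolates a change at this position. The added heavy atoms and hydrogen-bond acceptors of nitro leave the read-out level with that of chloro at this place. No measured evidence bears on why these two groups read alike. As far as these compounds go, whether other groups at this place, such as an amine or a carboxylic acid, also leave the read-out level stays open. From the compounds shown here alone, the effect of fluoro also stays open, as compound 1 differs from compound 2 in more than one place.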